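Same amide swap, now on the thiophene analogue

The compounds below may be only part of what the source reports. "The series", "measured", "known", "first", "only" and "open" are said of these compounds alone.

Compound 1 `CC1=C(C(=O)NC(C)C)C(c2ccco2)NC(=O)N1` is the reference. In an assay on membranes from HEK293 cells for displacement of a labelled ligand from adenosine receptor A2b (Homo sapiens), read by scintillation counting, with a stated time of 30 min, tested at 1 uM (a higher number here means more inhibition at the concentration tested (going by the name of the read-out), a lower number less inhibition), compound 1 gives 2%. Compound 2 `CCN(CC)C(=O)C1=C(C)NC(=O)NC1c1ccco1` differs by diethylamino in place of isopropylamino on a carbonyl carbon; in this assay compound 2 gives 31%, and a number 29 percentage points higher from compound 1 to compound 2 (beyond the scatter). Compound 3 `CC1=C(C(=O)NC(C)C)C(c2cccs2)NC(=O)N1` carries thiophen-2-yl in place of furan-2-yl on a saturated ring carbon; in this assay compound 3 gives 40%, and a number 38 percentage points higher from compound 1 to compound 3 (beyond the scatter). Compound 3 has the highest number of the three, though its gap to compound 2 lies within the scatter. Compound 4 `CCN(CC)C(=O)C1=C(C)NC(=O)NC1c1cccs1` is still unmeasured. It differs from compound 3 by diethylamino in place of isopropylamino on a carbonyl carbon, the same change that separates compound 1 from compound 2, at a place described in identical words. From compound 3 the expected step is a number 20 percentage points higher from compound 3 to compound 4 (beyond the scatter), somewhat smaller than a number 29 percentage points higher from compound 1 to compound 2 (beyond the scatter) because compound 3 already starts from 40% and a percentage read-out has less room upward. Compound 4 is therefore estimated at 60%, in the range 35% to 85%.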

Compound 4, a percentage reported as inhibition, at one concentration (the size of the read-out at that concentration, not a potency): 22%
Compound 4: the middle estimate sits 38 percentage points above what was measured; the measured number lies below the stated range.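

Diethylamino in place of isopropylamino on a carbonyl carbon did not carry over from the furan-2-yl pair to the thiophen-2-yl pair, where the result is a number 18 percentage points lower from compound 3 to compound 4 (beyond the scatter), and the two steps disagree: the same change on two cores in this assay, a number 29 percentage points higher (beyond the scatter) from compound 1 to compound 2 and a number 18 percentage points lower (beyond the scatter) from compound 3 to compound 4, 47 percentage points apart, beyond the scatter of two such steps

Read the other way, thiophen-2-yl in place of furan-2-yl did not carry over either, with a number 9 percentage points lower from compound 2 to compound 4 (within the scatter), so the rise seen on the isopropylamino amide is absent on the diethylamino amide: the same change on two cores in this assay, a number 38 percentage points higher (beyond the scatter) from compound 1 to compound 3 and a number 9 percentage points lower (within the scatter) from compound 2 to compound 4, 47 percentage points apart, beyond the scatter of two such steps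

The two changes are therefore not additive across these four compounds, but the data do not show why, nor which pair is the exception.

The compounds shown leave open how other amides, such as dimethylamino or pyrrolidine amides, behave on either core. They also leave open whether a phenyl group in place of furan-2-yl or thiophen-2-yl would follow either pattern.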